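This account rests on a few compounds, and the source may have more. Where it says the series, first, only, none or still open, it means among the compounds named here.

Compound 1, with the structure `CC(=O)c1cc(-c2ccccc2)cc2cc(-c3ccccc3)[nH]c12`, gives 99.3% in a functional assay on MCF7 cells (Homo sapiens) for cytotoxicity, read by MTT assay, with a stated time of 2 days, tested at 0.1 uM; a higher number here means a weaker effect of the compound at the concentration tested, a lower number a stronger effect.
Compound 2, with the structure `CC(=O)c1cc(-c2ccc(F)cc2)cc2cc(-c3ccccc3)[nH]c12`, gives 98.3% in this assay.
Compound 3, with the structure `CC(=O)c1cc(-c2ccccc2)cc2cc(-c3ccc(F)cc3)[nH]c12`, gives 98.5% in this assay.

All three numbers sit close together near the top of the scale, which means that at this concentration none of the compounds shows much of an effect. Compound 3 stands second highest of the three, but its gaps to compound 2 and to compound 1 both lie within the scatter, so no order among them can be read from these numbers.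

Compound 4, with the structure `COc1ccc(-c2cc(C(C)=O)c3[nH]c(-c4ccc(F)cc4)cc3c2)cc1`, is the next compound to be measured. Compared with compound 3 it carries methoxy in place of hydrogen on an aromatic carbon.

Within the data shown here, no measured step exchanges hydrogen for methoxy, so nothing bears on this change directly. The two steps that exist, a number 1 percentage points lower from compound 1 to compound 2 (within the scatter) and a number 0.8 percentage points lower from compound 1 to compound 3 (within the scatter), are each a single exchange on an aromatic carbon and each stays within the scatter. On that basis the expectation for this assay is a step of no size beyond the scatter, in either direction. The expected step is a number 1 percentage points lower from compound 3 to compound 4 (within the scatter). Compound 4 is therefore estimated at 97.5%, with a range from 90% to 101%.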

Compound 4, a percentage reported as activity, at one concentration (the size of the read-out at that concentration, not a potency): 88.4%
Compound 4: the middle estimate sits 9.1 percentage points above what was measured, and the stated range ends above it.
By their numbers in this assay, from the lowest: compounds 4, 2, 3 and 1 (each within the scatter of the next, the first and the last beyond it).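

In this assay, among these compounds, going from phenyl to 4-methoxyphenyl gives a number 10.1 percentage points lower from compound 3 to compound 4 (beyond the scatter), the only step in this set that lies beyond the scatter. Since a lower number means a stronger effect, this shows that an exchange on this aromatic carbon, para to a large group, can shift the read-out, which the fluoro exchange did not show with a number 1 percentage points lower from compound 1 to compound 2 (within the scatter); even so, compound 4 at 88.4% remains close to the top of the scale. Nothing available explains why methoxy produces this shift.

Going by these compounds, it remains open whether the shift belongs to the oxygen, to the size of the group or to the particular ring that carries it, and whether methoxy would act the same way without the fluoro on the other phenyl ring. A hydroxyl group, an ethoxy group or an amine at this same place would help separate these possibilities, and the tested concentration alone cannot say how potent any of these compounds is.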